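Swapping the pendant ring on the piperazine nitrogen

The compounds below may be only part of what the source reports. "The series", "measured", "known", "first", "only" and "open" are said of these compounds alone.

Compound 2 `Nc1ccccc1NC(=O)c1ccc(CSC(=S)N2CCN(Cc3ccncc3)CC2)cc1` carries a (pyridin-4-yl)methyl group on a ring nitrogen. In a functional assay on HeLa cells (Homo sapiens) for antiproliferative activity, read by CCK-8 assay, with a stated time of 72 h, tested at 8 uM (a lower number here means a weaker effect, a higher number a stronger effect of the compound at the concentration tested), compound 2 gives 72.9%, the highest of the three numbers measured here. Compound 3 `CC1CCN(C(=S)SCc2ccc(C(=O)Nc3ccccc3N)cc2)CC1` comes closest: in this assay compound 3 gives 72.5%, and the two values lie within the scatter of each other. Compound 1 `Nc1ccccc1NC(=O)c1ccc(CSC(=S)N2CCN(Cc3ccccn3)CC2)cc1` sits furthest away, giving 61.4% in this assay, and the step of a number 11.5 percentage points higher from compound 1 to compound 2 (beyond the scatter) is beyond the scatter.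

Compound 4 `Nc1ccccc1NC(=O)c1ccc(CSC(=S)N2CCN(c3ccccc3F)CC2)cc1` has not yet been measured. It differs from compound 2 in one place: 2-fluorophenyl in place of (pyridin-4-yl)methyl on an amine nitrogen in a ring.

Among the measured compounds shown here, only one measured step bears on this change, and only loosely. The step of a number 11.5 percentage points higher from compound 1 to compound 2 (beyond the scatter) shows that moving the nitrogen within the pyridine ring changed the read-out modestly. For the measured compounds named here, no measured pair shows an aromatic ring attached directly to the ring nitrogen, nor a fluorine on such a ring, so the effect of 2-fluorophenyl is not anchored by any measured step. Compound 3, which bears no pendant aromatic ring at all, gives a value within the scatter of compound 2, suggesting that the read-out is not very sensitive to what sits on this ring nitrogen.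

A step of a number 4.9 percentage points lower from compound 2 to compound 4 (within the scatter) within the scatter is therefore expected. The value for compound 4 is estimated at 68%, with a range from 52% to 82%.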

Compound 4, a percentage reported as inhibition, at one concentration (the size of the read-out at that concentration, not a potency): 59.2%
Compound 4: the middle estimate sits 8.8 percentage points above what was measured; low and high end bracket the measured number.
By their numbers in this assay, from the lowest: compounds 4 and 1 (each within the scatter of the next); then compounds 3 and 2 (each within the scatter of the next).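

In this assay the step of a number 13.7 percentage points lower from compound 2 to compound 4 (beyond the scatter) shows that this ring nitrogen does respond to the group it carries, at least when (pyridin-4-yl)methyl gives way to 2-fluorophenyl. The step of a number 2.2 percentage points lower from compound 1 to compound 4 (within the scatter) adds that the same 2-fluorophenyl group stands level with (pyridin-2-yl)methyl, so this change costs read-out only against the (pyridin-4-yl)methyl group, not against both pendant groups tried. Why these groups differ cannot be told, as no measurement here speaks to a cause.

The change from compound 2 to compound 4 alters several things at once: the ring nitrogen of the pyridine goes, the methyl link to the piperazine ring goes and a fluorine arrives, and the compounds shown cannot separate these parts. A plain phenyl group or a benzyl group on the same ring nitrogen would help to tell them apart, and so would a 4-fluorophenyl group, which would show whether the place of the fluorine on the ring matters.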